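This account rests on a few compounds, and the source may have more. Where it says the series, first, only, none or still open, it means among the compounds named here.

Compound 1 `CCCNc1nc(N)nc2ccccc12`: > 25000 nM (a limit)
Compound 2 `CCCCCNc1nc(N)nc2ccccc12`: > 25000 nM (a limit)
Compound 3 `CC(C)CCNc1nc(N)nc2ccccc12`: > 25000 nM (a limit)

These compounds were tested in an ADME assay on HEK293 cells (Homo sapiens) for cytotoxicity, with a stated time of 6 h (on this read-out lower numbers stand for higher toxicity in this test and higher numbers for lower toxicity in this test), and the picture is uniform: the limit of > 25000 nM in this assay, at which 3 of the 3 values shown sit. Compound 3 gives > 25000 nM, which is a limit and not a number.

Compound 4 `CCCC(C)Nc1nc(N)nc2ccccc12` differs from compound 3 only in how the chain is joined: 1-methylbutyl in place of isopentyl on a nitrogen on an aromatic ring. In words, this is 1-methylbutyl in place of isopentyl on a nitrogen on an aromatic ring.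

Within the data shown here, the steps that bear on this change also alter the chain: a step that the two limits leave unreadable from compound 1 to compound 2, a step that the two limits leave unreadable from compound 1 to compound 3 and a step that the two limits leave unreadable from compound 2 to compound 3. None of them has a readable size, so they show only that all three chains stay at the same limit. The expected result is a step that the limit leaves unreadable from compound 3 to compound 4, with no clear move in either direction, and a further limit is the likeliest report. For compound 4 the estimated value is 30000 nM, with an expected range of 18000 nM to 50000 nM.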

Compound 4, half-maximal cytotoxic concentration: > 25000 nM
Compound 4: a limit, no number; the forecaster's own chance of this, stated with the estimate: 85%; the middle value lies beyond the limit too.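

In this assay compound 4 gives > 25000 nM, a limit and not a number. Among these compounds, no step from compound 1, compound 2 or compound 3 to compound 4 can be read, and the set stays uniform: the limit of > 25000 nM in this assay, at which 4 of the 4 values shown sit. On these data alone, whether these chains differ at all in this test remains open.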